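Changing the Amide End of Compound 2

The source may hold more compounds than are shown below. What is called first, only, known or untested is meant among the compounds shown, and "the series" means these compounds.

In a functional assay on U-937 cells (Homo sapiens) for antiproliferative activity, read by MTT assay, with a stated time of 72 h (on this read-out higher numbers stand for weaker inhibition and lower numbers for stronger inhibition), compound 1 (`Nc1ccccc1NC(=O)CCCCCCc1nc(-c2ccc(C(F)(F)F)cc2)no1`) gives 5280 nM and compound 2 (`Nc1ccccc1NC(=O)CCCCCCc1nc(-c2cccc([N+](=O)[O-])c2)no1`) gives 2150 nM as the lower of the two numbers. Compound 3 (`O=C(CCCCCCc1nc(-c2cccc([N+](=O)[O-])c2)no1)C(F)(F)F`) carries trifluoromethyl in place of (2-aminophenyl)amino on a carbonyl carbon. Within the data shown here, the only measured step (a 2.5-fold lower number from compound 1 to compound 2 (0.39 log units; beyond the scatter)) is modest and swapped groups on an aromatic carbon, so no measurement covers this new change. A cautious guess is the expected 3.7-fold higher number from compound 2 to compound 3 (0.57 log units; beyond the scatter) as a modest loss. For compound 3 the estimated value in this assay is 8000 nM with an expected range of 2500 nM to 30000 nM here.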

Compound 3, half-maximal inhibitory concentration: 560 nM
Estimate against measurement, compound 3: 14-fold (1.15 log units) above, outside the stated range (below it).
By their numbers in this assay, from the lowest: compound 3; then compound 2; then compound 1.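

The amide end tolerates a large change: in this assay, trifluoromethyl in place of (2-aminophenyl)amino on a carbonyl carbon gives a 3.8-fold lower number from compound 2 to compound 3 (0.58 log units; beyond the scatter) as a step beyond the scatter. For this read-out, then, the aromatic ring and hydrogen-bond donors of the departing group are not needed for compound 3 to inhibit. No measured evidence says why the number falls. Still open, going by these compounds, is how a carboxylic acid or a hydroxamic acid would compare at this carbonyl carbon. Also open, on these data alone, is whether the same swap lowers the number when 4-(trifluoromethyl)phenyl replaces 3-nitrophenyl.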